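The compounds below may be only part of what the source reports. "The series", "measured", "known", "first", "only" and "open" are said of these compounds alone.

Of the compounds shown here, three built on a shared core have so far been measured in a physicochemical assay for lipophilicity; on this read-out lower numbers stand for lower lipophilicity and higher numbers for higher lipophilicity. Compound 1 `CC1CCCN(Cc2c(-c3nnc(SC(C)C)n3-c3ccccc3)n(C)c3ccc(F)cc23)C1` gives 6.18 in this assay, compound 2 `COc1ccc(CNCc2c(-c3nnc(SC(C)C)n3-c3ccccc3)n(C)c3ccc(F)cc23)cc1` gives 6.42, and compound 3 `CC1CCN(Cc2c(-c3nnc(SC(C)C)n3-c3ccccc3)n(C)c3ccccc23)CC1` gives 5.96. Among the compounds with values here, only one pair among them differs in a single place, and that step is a number 0.24 log units higher from compound 1 to compound 2 (within the scatter). Compound 3 holds the lowest of the three numbers: compound 1 stands nearest, higher by an amount within the scatter, and compound 2 stands furthest, higher by an amount beyond the scatter.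

Compound 4 `CC1CCN(Cc2c(-c3nnc(SC(C)C)n3-c3ccccc3)n(C)c3ccc(F)cc23)CC1` has not yet been measured in this assay. It differs from compound 3 by fluoro in place of hydrogen on an aromatic carbon. Within the data shown here, no measured step concerns this change: the one step known, from compound 1 to compound 2, swaps a different group and lies within the scatter. Compound 1 and compound 3 differ in two places, so their values cannot be separated into parts. On that basis compound 4 is expected to sit close to compound 3, with at most a small rise and no step beyond the scatter, a number 0.14 log units higher from compound 3 to compound 4 (within the scatter). Compound 4 is therefore estimated at 6.1 in this assay, in a range from 5.8 to 6.4.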

Compound 4, partition coefficient: 6.12
Estimate against measurement, compound 4: 0.02 log units below, and the stated range covers the measured number.
By their numbers in this assay, from the lowest: compounds 3, 4, 1 and 2 (each within the scatter of the next, the first and the last beyond it).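

In this assay, within the data shown here, fluoro in place of hydrogen on an aromatic carbon, meta to a fused ring and para to a fused ring, gives a number 0.16 log units higher from compound 3 to compound 4 (within the scatter) and so provides the first direct reading of this change, one that stays inside the scatter. With fluoro held in place on the shared core, two swaps on the saturated chain carbon bound to an aromatic carbon can now be read as well: 4-methylpiperidin-1-yl in place of (4-methoxybenzyl)amino gives a number 0.30 log units lower from compound 2 to compound 4 (within the scatter) and 4-methylpiperidin-1-yl in place of 3-methylpiperidin-1-yl gives a number 0.06 log units lower from compound 1 to compound 4 (within the scatter), so neither swap moves the number beyond the scatter. Nothing available explains the size of any of these steps.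

On these data alone, the fluoro change rests on a single pair carrying 4-methylpiperidin-1-yl, so it remains open whether it would read the same with (4-methoxybenzyl)amino or 3-methylpiperidin-1-yl on the chain carbon. As far as these compounds go, it also remains open whether chloro, methoxy or a nitrile on the same aromatic carbon, or a carboxylic acid or dimethylamino on the chain carbon, would give a step beyond the scatter.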